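Oxan-4-yl replaces 3-methoxyphenyl in a well-tolerated amide

The compounds below may be only part of what the source reports. "The series", "measured", "known", "first", "only" and "open" are said of these compounds alone.

In a toxicity assay on THP-1 cells (Homo sapiens) for inhibition (a higher number here means that more compound is tolerated, a lower number that less compound is tolerated), compound 3 (`COc1ccc(-c2cnc(NC(=O)c3cccc(OC)c3)n2C)cc1`) reads > 100000 nM, which is a limit and not a number. Compound 1 (`COc1ccc(-c2cnc(NC(=O)c3cnco3)n2C)cc1`) also gives only a limit, > 100000 nM. Compound 2 (`COc1ccc(-c2cnc(NC(=O)c3cccc(Cl)c3)n2C)cc1`) gives a limit too, > 28000 nM. Compound 4 (`COc1ccc(-c2cnc(NC(=O)C3CCOCC3)n2C)cc1`) has oxan-4-yl in place of 3-methoxyphenyl on a carbonyl carbon. The nearest precedents are changes on that same carbon, a step that the two limits leave unreadable from compound 1 to compound 3 and a step that the two limits leave unreadable from compound 1 to compound 2, and neither has a size that can be read. They therefore give no sign of a real shift, and the expected change in this assay is no more than the scatter: a number no higher from compound 3 to compound 4 (the limit leaves the size open). Compound 4 is estimated at 100000 nM, with an expected range from 30000 nM to 200000 nM.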

Compound 4, half-maximal cytotoxic concentration: > 100000 nM
Compound 4: only a limit was reported (the forecaster's own chance of this, stated with the estimate: 85%); the middle value sits exactly at the limit.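

Going by these compounds alone, compound 4, like compound 1, compound 2 and compound 3, gives only a limit in this assay, so no step between them can be read. The compounds shown leave open at what concentration any of them harms these cells.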